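The source may report more compounds than this note shows. Statements on the series, on what has been measured and on what is new or still open speak of the compounds shown alone.

Compound 1 `N#Cc1ccc(N2CCCc3c(-c4ccncc4)cccc32)cc1C(F)(F)F` was tested in a functional assay on CWR22R cells (Homo sapiens) for antiproliferative activity, read by CCK-8 assay, with a stated time of 6 days (on this read-out higher numbers stand for weaker inhibition and lower numbers for stronger inhibition), and in that test compound 1 gives 15000 nM. Among the two values shown, this is the only actual number. Compound 2 `CCN(c1cccc(-n2ccnc2)c1)c1ccc(C#N)c(Cl)c1` in this assay gives > 30000 nM, which is a limit of the assay rather than a number; this value is the limit of > 30000 nM in this assay, at which 1 of the 2 values shown sits. Compound 3 `Cn1nccc1-c1cccc2c1CCCN2c1ccc(C#N)c(C(F)(F)F)c1` has not yet been measured in this assay. It differs from compound 1 in one place: 1-methyl-1H-pyrazol-5-yl in place of pyridin-4-yl on an aromatic carbon. Within the data shown here, no step between measured compounds is available to show what such a swap does, so there is nothing beyond the two structures to lean on. The change exchanges one small aromatic ring for another of similar size, and the expected step is no change at the digits printed from compound 1 to compound 3 (within the scatter), within the usual scatter and with no clear direction. Compound 3 is therefore estimated at 15000 nM, with a range from 5000 nM to 40000 nM.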

Compound 3, half-maximal inhibitory concentration: 10400 nM
The estimate for compound 3 lay 1.4-fold (0.16 log units) above the measured number; the measured number falls inside the stated range.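

Placing 1-methyl-1H-pyrazol-5-yl on this aromatic carbon in place of pyridin-4-yl gives, in this assay, a 1.4-fold lower number from compound 1 to compound 3 (0.16 log units; within the scatter). Among these compounds, this is the first direct comparison at this position, and it shows that a five-membered aromatic ring with two hetero atoms and a six-membered aromatic ring with one hetero atom cannot be told apart in this test when the rest of the molecule stays the same. No measurement shown here offers an explanation for this result.

Going by these compounds, it remains open whether a group of a different kind on this carbon, such as an amine, a carboxylic acid or a longer chain, would shift the number beyond the scatter. A plain phenyl ring with no hetero atom is also untested among the compounds shown, so the part played by the ring nitrogens stays unknown.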